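A Chloro Swap on a Slowly Cleared Compound

The source may hold more compounds than are shown below. What is called first, only, known or untested is meant among the compounds shown, and "the series" means these compounds.

In an ADME assay on microsomes from liver (Rattus norvegicus) for metabolic stability, read by LC-MS, using NADPH, with a stated time of 30 min, tested at 1 uM (a higher number here means faster removal of the compound, a lower number slower removal), compound 1 `CC#Cc1cncc(-c2ccc3c(c2)[C@@]2(COC(N)=N2)c2cc(-c4ccnc(F)c4)ncc2O3)c1` gives 20 mL.min-1.g-1 and compound 2 `CC#Cc1cncc(-c2ccc3c(c2)[C@@]2(COC(N)=N2)c2cc(C4=CCCOC4)ncc2O3)c1` gives 45 mL.min-1.g-1.

Compound 3 `NC1=N[C@@]2(CO1)c1cc(NC(=O)c3ccc(Cl)cn3)ccc1Oc1cnc(C3CC3)cc12` gives < 14 mL.min-1.g-1 in this assay, and this is a limit of the assay, not a number. Compound 3 therefore stands at the limit of < 14 mL.min-1.g-1 in this assay, at which 1 of the 3 values shown sits.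

Compound 4 `NC1=N[C@@]2(CO1)c1cc(NC(=O)c3ccc(Cl)cn3)ccc1Oc1cnc(Cl)cc12` keeps the rest of compound 3 but carries chloro in place of cyclopropyl on an aromatic carbon. That carbon lies next to the ring nitrogen.

Among the compounds with values here, only one measured step bears on this change, and only loosely. It is a 2.3-fold higher number from compound 1 to compound 2 (0.35 log units; beyond the scatter), a modest change that also swaps one group for another on an aromatic carbon. The groups and the rest of the molecule differ there, so it offers a guide to size but none to direction.

Going by that step, a modest change at most is expected here, and its direction remains open. On these data alone, the estimated step is a number no lower from compound 3 to compound 4 (the limit leaves the size open), though the true start is unknown and the result could again be only a limit. For compound 4 the estimated value is 14 mL.min-1.g-1, with an expected range of 8 mL.min-1.g-1 to 28 mL.min-1.g-1.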

Compound 4, intrinsic clearance in microsomes: < 14 mL.min-1.g-1
Compound 4 gave a limit, no number; the forecaster's own chance of this, stated with the estimate: 50%; the middle value lies on the limit itself.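

No step from compound 3 to compound 4 can be read in this assay, because each gives only a limit of the assay rather than a number: the limit of < 14 mL.min-1.g-1 in this assay, at which 2 of the 4 values shown sit.

The compounds shown leave open how quickly compound 3 and compound 4 are actually removed, and whether chloro in place of cyclopropyl changes that rate at all.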